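Series notes: aryl ether to aryl thioether at the core

The compounds below may be only part of what the source reports. "The series", "measured", "known", "first", "only" and "open" are said of these compounds alone.

Compound 1 `Nc1cc(N)c2nc(-c3ccccc3)c(Oc3ccc(F)cc3)nc2c1` is measured in a functional assay on SK-MEL-5 cells (Homo sapiens) for inhibition, read by sulforhodamine B assay, with a stated time of 48 h (on this read-out lower numbers stand for stronger inhibition of growth and higher numbers for weaker inhibition of growth), where compound 1 gives 31600 nM. Compound 2 `COc1ccc(CNc2nc3cc(N)cc(N)c3nc2-c2ccccc2)cc1OC` gives 27500 nM in this assay, and compound 3 `COc1ccc(CNc2nc3cc(N)cc(N)c3nc2-c2ccccc2)cc1` gives 31600 nM. On these numbers compound 1 stands level with compound 3 at the digits shown, the pair together giving the highest numbers of the three, and compound 2 sits a shade lower, within the scatter of both. Among the compounds with values here, the one step between measured compounds, a 1.1-fold higher number from compound 2 to compound 3 (0.06 log units; within the scatter), shows hydrogen in place of methoxy on an aromatic carbon leaving the number essentially where it was.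

Compound 4 `COc1ccc(Sc2nc3cc(N)cc(N)c3nc2-c2ccccc2)cc1` is the next member to be measured. Its change from compound 1: (4-methoxyphenyl)sulfanyl in place of 4-fluorophenoxy on an aromatic carbon. Within the data shown here, no measured step touches this exchange of ether oxygen for sulfur, nor the swap of fluorine for methoxy on the pendant ring, so nothing points to a move beyond the scatter. The estimated step is therefore a 1.1-fold lower number from compound 1 to compound 4 (0.02 log units; within the scatter), and compound 4 is expected to give about 30000 nM in this assay, within a range of 10000 nM to 90000 nM.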

Compound 4, concentration for total growth inhibition: < 100000 nM
Compound 4 was reported as a limit; the forecaster's own chance of this, stated with the estimate: 15%; the middle value does not contradict the limit.
By their numbers in this assay, from the lowest: compounds 2, 1 and 3 (each within the scatter of the next).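

In this assay compound 4 gives < 100000 nM, which is a limit and not a number. Within the data shown here, no step from compound 1 to compound 4 can be read from it. The compounds shown leave open whether (4-methoxyphenyl)sulfanyl in place of 4-fluorophenoxy moves the number at all, and in which direction.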